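The source may hold more compounds than are shown below. What is called first, only, known or untested is meant among the compounds shown, and "the series" means these compounds.

Compound 3 `COc1ccc2c(c1)OC(c1cc(OC)c(OC)c(OC)c1)C(/C=N/O)=C2` gives, in a functional assay for inhibition of nuclear factor NF-kappa-B complex (Homo sapiens) (on this read-out lower numbers stand for stronger inhibition and higher numbers for weaker inhibition), 14100 nM, the lowest of the two numbers shown; its nearest neighbour, compound 2 `COc1ccc2c(c1)OC(c1cc(OC)c(OC)c(OC)c1)C(C(=O)OCCc1ccccc1)=C2`, gives 16200 nM, a gap within the scatter (a 1.1-fold lower number from compound 2 to compound 3 (0.06 log units; within the scatter)). Compound 1 `COc1ccc2c(c1)OC(c1cc(OC)c(OC)c(OC)c1)C(CO)=C2` reaches only a limit of the assay, > 50000 nM. The change to compound 4 `COc1ccc2c(c1)OC(c1cc(OC)c(OC)c(OC)c1)C(C#N)=C2` is a group of 2 heavy atoms (1 carbon, 1 nitrogen; no ring) in place of a group of 3 heavy atoms (1 carbon, 1 nitrogen, 1 oxygen; no ring), on a double-bonded ring carbon. Among the measured compounds shown here, two measured steps bear on it: an at least 3.0-fold lower number from compound 1 to compound 2 (0.48 log units; beyond the scatter) and an at least 3.5-fold lower number from compound 1 to compound 3 (0.54 log units; beyond the scatter), both beyond the scatter, whereas the exchange of the large phenethyloxycarbonyl for the small oxime-type group (a 1.1-fold lower number from compound 2 to compound 3 (0.06 log units; within the scatter)) stayed within it. For the measured compounds named here, only the step away from hydroxymethyl moved the number clearly; the present step goes toward a smaller group again. Compound 4 is therefore expected to shift by a 1.6-fold higher number from compound 3 to compound 4 (0.19 log units; within the scatter) in this assay, to an estimated 22000 nM, with a range from 8000 nM to 60000 nM.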

Compound 4, half-maximal inhibitory concentration: 3400 nM
For compound 4 the middle estimate is 6.5-fold (0.81 log units) above the measured one; the measured number lies below the stated range.
By their numbers in this assay, from the lowest: compound 4; then compounds 3 and 2 (each within the scatter of the next). At a limit, above all of these: compound 1.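

With cyano on the double-bonded ring carbon, the number in this assay falls clearly: a 4.1-fold lower number from compound 3 to compound 4 (0.62 log units; beyond the scatter), and a 4.8-fold lower number from compound 2 to compound 4 (0.68 log units; beyond the scatter). Heavy-atom count alone does not order these groups, since cyano and hydroxymethyl each hold 2 heavy atoms, yet there is an at least 14-fold lower number from compound 1 to compound 4 (1.16 log units; beyond the scatter). Compound 1 stands at a limit of the assay, so that step is only a bound: the limit of > 50000 nM in this assay, at which 1 of the 4 values shown sits.

As far as these compounds go, how a carboxylic acid, a primary amide or an amine would compare at this position remains open. So does whether the cyano step holds when the methoxy groups on the shared core change.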